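From tert-butyl to cyclohexyl: compound 1 to compound 4

The compounds below may be only part of what the source reports. "The series", "measured", "known", "first", "only" and "open" are said of these compounds alone.

Compound 1 `CC1(c2ccc(NC(c3ccc(Cl)cc3)c3nnnn3C(C)(C)C)cc2)NC(=O)c2ccccc2N1`: > 400000 nM
Compound 2 `COc1ccc(C(Nc2ccc(C3(C)NC(=O)c4ccccc4N3)cc2)c2nnnn2C(C)(C)C)cc1`: > 400000 nM
Compound 3 `COc1ccc(C(Nc2ccc(C3(C)NC(=O)c4ccccc4N3)cc2)c2nnnn2C(C)(C)C)c2ccccc12`: "not determined" (no result reported)

In an ADME assay on Vero cells (Chlorocebus sabaeus) for cytotoxicity, read by MTT assay, with a stated time of 72 h (a higher number here means that more compound is tolerated, a lower number that less compound is tolerated), compound 1 stands at > 400000 nM, which is a limit and not a number. Compound 2, with > 400000 nM, also gives only a limit. Among the measured compounds shown here, the one measured step, methoxy in place of chloro on an aromatic carbon, is a step that the two limits leave unreadable from compound 1 to compound 2, so it offers no size to carry over. What remains is the limit of > 400000 nM in this assay, at which 2 of the 3 values shown sit.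

Compound 4 `CC1(c2ccc(NC(c3ccc(Cl)cc3)c3nnnn3C3CCCCC3)cc2)NC(=O)c2ccccc2N1` differs from compound 1 at another place: cyclohexyl in place of tert-butyl on an aromatic nitrogen. For the measured compounds named here, no measured step covers this change. No step beyond the scatter is expected in this assay. The estimated step is a number no higher from compound 1 to compound 4 (the limit leaves the size open). For compound 4 the expected value is 400000 nM, with an estimated range of 150000 nM to 800000 nM.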

Compound 4, half-maximal cytotoxic concentration: > 400000 nM
Compound 4: no number, only a limit; the forecaster's own chance of this, stated with the estimate: 70%; the middle value lies on the limit itself.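

Compound 4, at > 400000 nM, gives a limit and not a number; compound 1 also gives only a limit, so no new step can be read between them. The compounds shown leave open the concentration at which any of them reaches half-maximal cytotoxicity.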